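This account rests on a few compounds, and the source may have more. Where it says the series, first, only, none or still open, it means among the compounds named here.

Measured compounds:
- compound 1 `C=CCn1c(=O)/c(=C\c2cccc(F)c2)[nH]c(=O)/c1=C\c1ccccc1OC`: in a functional assay on K562 cells (Homo sapiens) for cytotoxicity, read by CCK-8 assay, with a stated time of 72 h (a lower number here means a stronger inhibitor, a higher number a weaker inhibitor), compound 1 gives 4100 nM
- compound 2 `C=CCn1c(=O)/c(=C\c2cccc(Cl)c2Cl)[nH]c(=O)/c1=C\c1ccccc1OC`: in this assay compound 2 gives 900 nM
- compound 3 `C=CCn1c(=O)/c(=C\c2ccccc2OC)[nH]c(=O)/c1=C\c1ccccc1OC`: in this assay compound 3 gives 7400 nM

Compound 3 has the highest number of the three. Its nearest neighbour is compound 1 (a 1.8-fold higher number from compound 1 to compound 3 (0.26 log units; within the scatter)), its furthest compound 2 (an 8.2-fold higher number from compound 2 to compound 3 (0.91 log units; beyond the scatter)). The shared core is kept throughout, and only the aryl group on the double-bonded chain carbon changes.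

Compound 4 `C=CCn1c(=O)/c(=C\c2ccccc2C(F)(F)F)[nH]c(=O)/c1=C\c1ccccc1OC` is not yet measured. It differs from compound 3 by trifluoromethyl in place of methoxy on an aromatic carbon. Among the compounds with values here, no measured step covers a trifluoromethyl group; the steps that bear on it are the aryl swaps at the same position, namely a 4.6-fold lower number from compound 1 to compound 2 (0.66 log units; beyond the scatter) and an 8.2-fold higher number from compound 2 to compound 3 (0.91 log units; beyond the scatter), which show that a halogenated aryl ring there gives a clearly lower number than the methoxy-bearing one, while the fluorine-only ring of compound 1 sits within the scatter of compound 3. Compound 4 is therefore expected to land below compound 3 in this assay, with a step of a 3.0-fold lower number from compound 3 to compound 4 (0.47 log units; beyond the scatter), though the direction is uncertain. The estimate for compound 4 is 2500 nM, in the range 900 nM to 7000 nM.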

Compound 4, half-maximal inhibitory concentration: 2700 nM
Compound 4: the middle estimate sits 1.1-fold (0.03 log units) below what was measured; the range from low to high includes it.
By their numbers in this assay, from the lowest: compound 2; then compounds 4, 1 and 3 (each within the scatter of the next, the first and the last beyond it).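

Working notes on the aryl position, read in this assay: on an aromatic carbon ortho to a large group, trifluoromethyl in place of methoxy gives a 2.7-fold lower number from compound 3 to compound 4 (0.44 log units; beyond the scatter) and so shows, for the first time, a step beyond the scatter from a change of this single group on the 2-methoxyphenyl ring. The result also separates two halogen-bearing rings, since a 3.0-fold higher number from compound 2 to compound 4 (0.48 log units; beyond the scatter) leaves the 2-(trifluoromethyl)phenyl ring short of the 2,3-dichlorophenyl ring, and compound 2 keeps the lowest number of the four, with its steps to all three others beyond the scatter. Against the 3-fluorophenyl ring the reading is a 1.5-fold lower number from compound 1 to compound 4 (0.18 log units; within the scatter) and lies within the scatter, so these two rings cannot be told apart here, although compound 1 stays within the scatter of compound 3 while compound 4 does not.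

No measurement available here bears on the reason for any of these differences. As far as these compounds go, it also remains open whether an amine, a carboxylic acid or a nitrile on this aryl ring, or a chlorine added to the 2-(trifluoromethyl)phenyl ring, would reach the number of compound 2.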